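A few compounds are considered here, and "the series" means these few. Any claim that something is new, unique, unknown or untested is made for them only; others in the source may bear on it.

Within the data shown here, in an ADME assay on MT4 cells (Homo sapiens) for cytotoxicity, read by MTT assay, with a stated time of 4 days (on this read-out lower numbers stand for higher toxicity in this test and higher numbers for lower toxicity in this test), compound 1 `CCCNc1nc(C(C)c2c(F)cccc2F)c(C)c(=O)[nH]1` gives 35000 nM, the only exact number among the three compounds measured so far. Compound 2 `CCN(C)c1nc(Cc2c(F)cccc2F)cc(=O)[nH]1`, whose amino group is fully substituted, as dimethylamino is, gives only a limit, > 89000 nM. Compound 3 `Cc1c(Cc2c(F)cccc2F)nc(N(C)C2CCCCC2)[nH]c1=O`, also fully substituted on that amino group, likewise gives only a limit, > 72000 nM. Among the measured compounds shown here, neither limit can be read as an exact distance from compound 1, and both compounds differ from it in more than one place, so there is no clean measured step to borrow.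

Compound 4 `Cc1c(C(C)c2c(F)cccc2F)nc(N(C)C)[nH]c1=O` keeps the rest of compound 1 and changes one group: dimethylamino in place of propylamino on an aromatic carbon, between two ring nitrogen atoms (dimethylamino in place of propylamino on an aromatic carbon). The expected change, a 1.7-fold higher number from compound 1 to compound 4 (0.23 log units; within the scatter), is modest and points towards higher numbers, which would mean lower toxicity in this assay. This expectation leans on compound 3, whose result is a limit, > 72000 nM. It is only a weak guide, since the evidence comes from so few compounds, and a result reported only as a limit is quite possible. For compound 4 the estimated value is 60000 nM, with an expected range from 25000 nM to 110000 nM.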

Compound 4, half-maximal cytotoxic concentration: > 17000 nM
Compound 4 was reported as a limit; the forecaster's own chance of this, stated with the estimate: 50%; the middle value is on the limit's open side.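

In this assay compound 4 gives > 17000 nM, which is a limit and not an exact number. The size of the step between compound 1 and compound 4 cannot be read from it. The compounds shown leave open whether dimethylamino in place of propylamino on this core changes the read-out at all, and in which direction.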